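Removing the Nitro Group From Compound 3

The compounds below may be only part of what the source reports. "The series", "measured", "known", "first", "only" and "open" are said of these compounds alone.

Compound 3 `COc1ccc([C@@H]2C(c3cccs3)C(=O)N2c2cc(OC)c(OC)c(OC)c2)cc1[N+](=O)[O-]` gives 370 nM in a functional assay on MCF7 cells (Homo sapiens) for antiproliferative activity, read by MTT assay (a lower number here means a stronger inhibitor, a higher number a weaker inhibitor), the second highest of the three numbers recorded; compound 1 `COc1ccc([C@@H]2C(c3ccsc3)C(=O)N2c2cc(OC)c(OC)c(OC)c2)cc1` gives 60 nM and compound 2 `COc1ccc([C@@H]2C(Cc3cccs3)C(=O)N2c2cc(OC)c(OC)c(OC)c2)cc1` gives 1640 nM. For the measured compounds named here, the one step measured between compounds differing in a single place, a 27-fold higher number from compound 1 to compound 2 (1.44 log units; beyond the scatter), concerns the group on the saturated ring carbon, not the aromatic ring changed here, so it does not bear on the present change. Compound 4 `COc1ccc([C@@H]2C(c3cccs3)C(=O)N2c2cc(OC)c(OC)c(OC)c2)cc1` differs from compound 3 by hydrogen in place of nitro on an aromatic carbon. Going by the values given here, no measured pair isolates this change; the closest guide is compound 1, which carries the same 4-methoxyphenyl with thiophen-3-yl instead of thiophen-2-yl, and gives 60 nM. Compound 4 is therefore expected to fall between those figures, at an estimated 110 nM (range 30 nM to 400 nM), meaning an expected step of a 3.4-fold lower number from compound 3 to compound 4 (0.53 log units; beyond the scatter).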

Compound 4, half-maximal inhibitory concentration: 64 nM
For compound 4 the middle estimate is 1.7-fold (0.24 log units) above the measured one; the measured number falls inside the stated range.
By their numbers in this assay, from the lowest: compounds 1 and 4 (each within the scatter of the next); then compound 3; then compound 2.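

Taking off the nitro group gives the first direct reading at this aromatic carbon: in this assay there is a 5.8-fold lower number from compound 3 to compound 4 (0.76 log units; beyond the scatter), so the compound with hydrogen there is the stronger of the pair. Compound 4 also links the other compounds through the group on the saturated ring carbon: a 1.1-fold higher number from compound 1 to compound 4 (0.03 log units; within the scatter) shows that thiophen-2-yl and thiophen-3-yl cannot be told apart here. Meanwhile, a 26-fold lower number from compound 2 to compound 4 (1.41 log units; beyond the scatter) shows that thiophen-2-yl directly on that carbon far outperforms (thiophen-2-yl)methyl. Nothing measured here explains these steps. On these data alone, whether an amine or a hydroxyl group on that aromatic carbon would read like hydrogen or like nitro remains open.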